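The compounds below may be only part of what the source reports. "The series", "measured", "known", "first", "only" and "open" are said of these compounds alone.

Among the measured compounds shown here, compound 1 `CC(C)COc1ncc(-c2cn(C)c3cc(C(=O)NS(C)(=O)=O)ccc23)cc1Cl` is one of only two compounds measured so far. In an ADME assay on a cell-free system (plasma, Mus musculus) for protein binding (a lower number here means a smaller unbound share, a higher number a larger unbound share of the compound), compound 1 gives 0.002, and compound 2 `CC(C)Cc1ccc(-c2cn(C)c3cc(C(=O)NS(C)(=O)=O)ccc23)cc1` gives 0.003 in this assay , a gap that lies within the usual scatter, so the two stand together at a small unbound share. The step followed here leads to compound 3 `CC(C)COc1ncc(-c2cn(C)c3cc(C(=O)NS(C)(=O)=O)c(F)cc23)cc1Cl`, which differs from compound 1 by fluoro in place of hydrogen on an aromatic carbon. For the measured compounds named here, no measured pair shows what such a change does, so the expectation rests on compound 1 alone. The expected step is a 1.3-fold lower number from compound 1 to compound 3 (0.12 log units; within the scatter), small, if anything toward a smaller unbound share. For compound 3 the estimate in this assay is 0.0015, between 0.0007 and 0.004.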

Compound 3, unbound fraction: 0.002
Estimate against measurement, compound 3: 1.3-fold (0.12 log units) below; low and high end bracket the measured number.
By their numbers in this assay, from the lowest: compounds 1, 3 and 2 (each within the scatter of the next).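

In this assay, fluoro in place of hydrogen on this aromatic carbon, ortho to a (methylsulfonyl)carbamoyl group, gives no change at the digits printed from compound 1 to compound 3 (within the scatter). Among the compounds shown here, this is the first measured single-place step, and it shows that this position accepts a fluoro with the unbound share staying small. Nothing measured here offers an explanation for this result. Going by these compounds, whether an amine or a methoxy group at the same carbon would shift the unbound share remains open. So does whether fluoro behaves alike on compound 2.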